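From 4-methylphenyl to 2,4,6-trimethylphenyl in compound 2

This account rests on a few compounds, and the source may have more. Where it says the series, first, only, none or still open, it means among the compounds named here.

Values so far in a functional assay on HepG2 cells (Homo sapiens) for inhibition, read by MTT assay, with a stated time of 48 h; a lower number here means a stronger inhibitor, a higher number a weaker inhibitor

compound 1 (`Cc1ccc(/C=C2\SC(=O)N(CCNC(=O)Nc3c(C)n(C)n(-c4ccccc4)c3=O)C2=O)cc1`) gives 25700 nM
compound 2 (`Cc1ccc(/C=C2\SC(=O)N(CC(=O)Nc3c(C)n(C)n(-c4ccccc4)c3=O)C2=O)cc1`) gives 57600 nM

Compound 2 holds the higher of the two numbers and is the weaker inhibitor here, with compound 1 lower by more than the usual scatter. Compound 3 (`Cc1cc(C)c(/C=C2\SC(=O)N(CC(=O)Nc3c(C)n(C)n(-c4ccccc4)c3=O)C2=O)c(C)c1`) carries one change from compound 2 (2,4,6-trimethylphenyl in place of 4-methylphenyl on a double-bonded chain carbon bound to a double-bonded ring carbon) with 2,4,6-trimethylphenyl in place of 4-methylphenyl on a double-bonded chain carbon bound to a double-bonded ring carbon. Going by the values given here, no two measured compounds differ in one place only, so the series gives no direct guide to this change in this assay and any step remains a judgement. The expectation therefore starts from compound 2 at 57600 nM and assumes no shift beyond the scatter. The estimated step (a 1.2-fold lower number from compound 2 to compound 3 (0.06 log units; within the scatter)) is expected to stay within the scatter. For compound 3 the estimate is 50000 nM with an expected range from 20000 nM to 125000 nM in this measurement.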

Compound 3, half-maximal inhibitory concentration: 63500 nM
The estimate for compound 3 lay 1.3-fold (0.10 log units) below the measured number; the measured number falls inside the stated range.
By their numbers in this assay, from the lowest: compound 1; then compounds 2 and 3 (each within the scatter of the next).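

In this assay the exchange of 4-methylphenyl for 2,4,6-trimethylphenyl gives a 1.1-fold higher number from compound 2 to compound 3 (0.04 log units; within the scatter). Going by these compounds alone, this is the first step that can be read at a single place, and it shows that on a double-bonded chain carbon bound to a double-bonded ring carbon, a carbon-only aromatic group of 9 heavy atoms reads the same as one of 7 within the scatter. No measurement on hand offers an explanation for this result.

The compounds shown leave open whether a group carrying an amine or a carboxylic acid on the phenyl ring at this place would move the number beyond the scatter. Also open, on these data alone, is whether the same exchange made on compound 1 would again stay within the scatter.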